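Replacing an aromatic ring with a 3-oxomorpholin-4-yl group

This account rests on a few compounds, and the source may have more. Where it says the series, first, only, none or still open, it means among the compounds named here.

Measured so far:
compound 1 `COc1cc(OCc2csc(-c3ccc(C(F)(F)F)cc3)n2)c2cc(-c3cn4nc(OC)sc4n3)oc2c1` — 1.3 nM
compound 2 `COc1cc(OCc2csc(-c3ccc(S(C)(=O)=O)cc3)n2)c2cc(-c3cn4nc(OC)sc4n3)oc2c1` — 0.8 nM

Of the compounds shown here, two have been tested in a functional assay on HEK293 cells for antagonist activity at proteinase-activated receptor 4 (Homo sapiens), read by FLIPR and calcium flux, with a stated time of 30 min; a higher number here means a weaker inhibitor, a lower number a stronger inhibitor. Compound 1 gives 1.3 nM, and compound 2 gives 0.8 nM. Of these two numbers compound 1 has the higher one, but the step of a 1.6-fold lower number from compound 1 to compound 2 (0.21 log units; within the scatter) is within the scatter, so the two cannot be told apart.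

Compound 3 `COc1cc(OCc2csc(N3CCOCC3=O)n2)c2cc(-c3cn4nc(OC)sc4n3)oc2c1` has not yet been measured. It differs from compound 1 in one place: 3-oxomorpholin-4-yl in place of 4-(trifluoromethyl)phenyl on an aromatic carbon. An aromatic ring of carbon only leaves, and a six-membered non-aromatic ring with a double bond outside aromatic rings enters, at the same position on the five-membered ring.

Among the compounds with values here, the only step known, from compound 1 to compound 2, exchanged one group on the aromatic ring that is now removed entirely, so it bears on this change only loosely. It shows that a change on that ring need not move the number. Removing the ring itself is a larger change, and for compound 3 a weaker result than compound 1 is expected, with a 3.8-fold higher number from compound 1 to compound 3 (0.59 log units; beyond the scatter). Compound 3 is estimated at 5 nM, within a range from 1 nM to 40 nM.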

Compound 3, half-maximal inhibitory concentration: 1.7 nM
Beside the measured number, compound 3's estimate is 2.9-fold (0.47 log units) above it; the measured number falls inside the stated range.
By their numbers in this assay, from the lowest: compounds 2, 1 and 3 (each within the scatter of the next, the first and the last beyond it).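

Swapping the whole 4-(trifluoromethyl)phenyl group for 3-oxomorpholin-4-yl gives, in this assay, a 1.3-fold higher number from compound 1 to compound 3 (0.12 log units; within the scatter). So on this carbon of the five-membered ring, which lies next to the ring nitrogen and the ring sulfur, an aromatic ring of carbon only is not required for a low-nanomolar number, at least with the core of compound 1; the earlier step changed only a group on that ring, whereas this one removes the ring itself. The same exchange made against 4-(methylsulfonyl)phenyl gives a 2.1-fold higher number from compound 2 to compound 3 (0.33 log units; beyond the scatter), a modest step, so compound 2 keeps a small edge over compound 3 even though compound 1 and compound 3 cannot be told apart.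

On these data alone, it remains open which part of the new ring matters, and a plain morpholin-4-yl group without the carbonyl, a piperidin-2-one ring without the ring oxygen, or an open-chain amide on the same carbon would separate these parts. Nothing measured here gives a reason why the non-aromatic ring matches the aromatic one so closely.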